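The compounds below may be only part of what the source reports. "The series", "measured", "known", "first", "only" and "open" are said of these compounds alone.

The series shares one core, a fused bicyclic system carrying a phenylethynyl group, and the compounds were tested in an assay on HEK293 cells for negative allosteric modulation of metabotropic glutamate receptor 5 (Homo sapiens), read by FLIPR, with a stated time of 1 h; on this read-out lower numbers stand for stronger inhibition and higher numbers for weaker inhibition. Compound 1 `Cc1cccc(C#Cc2nc3c(s2)C(=O)NCC3)c1` gives only a limit in this assay, > 10000 nM. Compound 2 `O=C1c2sc(C#Cc3ccccc3)nc2CN1C1CC1` gives 23 nM in this assay. Compound 3 `C(#Cc1nc2c(s1)CN(C1CCCCC1)CC2)c1ccccc1` also gives only a limit, > 10000 nM. Compound 3 thus stands at the weak end of what has been measured, sitting at the limit described by the limit of > 10000 nM in this assay, at which 2 of the 3 values shown sit, whereas compound 2 alone returns a numerical value.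

Compound 4 `O=C(C1CCCO1)N1CCc2nc(C#Cc3ccccc3)sc2C1` has not yet been measured. It differs from compound 3 in one place: (oxolan-2-yl)carbonyl in place of cyclohexyl on an amine nitrogen in a ring. Within the data shown here, no measured step involves this change, so its size can only be judged against the other two compounds. Compound 3 reaches no numerical value, and a measurable result for compound 4 would by itself be a gain beyond the scatter. Such a gain is expected, though not one large enough to bring compound 4 to the level of compound 2. Compound 4 is estimated at 300 nM in this assay, with a range from 50 nM to 3000 nM. The expected step is an at least 33-fold lower number from compound 3 to compound 4 (1.52 log units; beyond the scatter).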

Compound 4, half-maximal inhibitory concentration: > 10000 nM
Compound 4 gave a limit, no number (the forecaster's own chance of this, stated with the estimate: 25%); middle value at least 33-fold (1.52 log units) from the limit.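

Among these compounds, compound 3 and compound 4 each give only a limit in this assay, so no step between them can be read. Compound 4 joins the compounds at that limit: the limit of > 10000 nM in this assay, at which 3 of the 4 values shown sit. The compounds shown leave open whether (oxolan-2-yl)carbonyl in place of cyclohexyl changes inhibition at all.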